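The source may hold more compounds than are shown below. What is called first, only, known or untested is meant among the compounds shown, and "the series" means these compounds.

Measured so far in an assay on isolated protein for inhibition of ribosomal protein S6 kinase alpha-2 (Homo sapiens), with a stated time of 150 min; a higher number here means a weaker inhibitor, a lower number a stronger inhibitor: compound 1 `COc1cccc(F)c1-c1cccc2nc(N)oc12` gives 2800 nM; compound 2 `COc1cc(Nc2nc3cccc(-c4c(F)cccc4OC)c3o2)cc(OC)c1OC` gives 20 nM; compound 3 `COc1cc(Nc2nc3cccc(-c4c(F)cccc4OC)c3o2)cc(OC)c1` gives 210 nM.

Compound 2 holds the lowest number of the three, with compound 3 nearest and compound 1 furthest. For the measured compounds named here, the only single-point step measured is an 11-fold higher number from compound 2 to compound 3 (1.02 log units; beyond the scatter), a hydrogen in place of methoxy on an aromatic carbon of the amine ring. Compound 4 `COc1ccccc1-c1cccc2nc(Nc3cc(OC)c(OC)c(OC)c3)oc12` differs from compound 2 by hydrogen in place of fluoro on an aromatic carbon. Going by the values given here, no measured step touches this ring; compound 1 carries the same 2-fluoro-6-methoxyphenyl but differs from compound 2 in more than one place, so it gives no guide to the fluoro alone. The step is therefore expected to be modest, a 2.5-fold higher number from compound 2 to compound 4 (0.40 log units; beyond the scatter), with wide uncertainty. Compound 4 is estimated at 50 nM, likely between 15 nM and 200 nM.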

Compound 4, half-maximal inhibitory concentration: 20 nM
Beside the measured number, compound 4's estimate is 2.5-fold (0.40 log units) above it; low and high end bracket the measured number.
By their numbers in this assay, from the lowest: compounds 2 and 4 (each within the scatter of the next); then compound 3; then compound 1.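

In this assay, for the compounds shown here, the step of no change at the digits printed from compound 2 to compound 4 (within the scatter) is the first reading on the 2-fluoro-6-methoxyphenyl ring: fluoro can give way to hydrogen on this aromatic carbon with no loss beyond the scatter. The earlier step of an 11-fold higher number from compound 2 to compound 3 (1.02 log units; beyond the scatter) concerned a methoxy elsewhere in the molecule, so sensitivity there does not extend to this position. No supporting data bear on why this change is tolerated.

Still open, going by these compounds, is whether this carbon accepts anything larger than fluoro, such as chloro, methyl or an amine. The role of the remaining methoxy on this ring, for instance against hydroxy or ethoxy, is also unresolved.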